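Bromo to hydroxy swap in the antiproliferative series

A few compounds are considered here, and "the series" means these few. Any claim that something is new, unique, unknown or untested is made for them only; others in the source may bear on it.

Going by the values given here, in a functional assay on A549 cells (Homo sapiens) for antiproliferative activity, read by MTT assay, with a stated time of 48 h (on this read-out higher numbers stand for weaker inhibition and lower numbers for stronger inhibition), compound 1 (`COc1ccc(C(=O)c2ccc(OC)c3c2C=CC(C)(C)O3)c(NC(=O)CBr)c1`) gives 2460 nM, the highest of the three numbers so far. Compound 2 (`COc1ccc(C(=O)c2ccc3c(c2)C=CC(C)(C)O3)c(NC(=O)CBr)c1`) gives 1980 nM, within the scatter of compound 1, and it also carries the bromo group. Compound 3 (`COc1ccc(C(=O)c2ccc(OC)c3c2OC(C)(C)C=C3)c(NC(=O)CO)c1`) gives 80 nM, a much lower number and beyond the scatter from compound 1. Compound 3 carries hydroxy instead of bromo, but its core also differs from that of compound 1.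

The next compound is compound 4 (`COc1ccc(C(=O)c2ccc(OC)c3c2C=CC(C)(C)O3)c(NC(=O)CO)c1`), which keeps the core of compound 1 and changes one group: hydroxy in place of bromo on a saturated chain carbon bound to a carbonyl carbon. In words, hydroxy stands in place of bromo on a saturated chain carbon bound to a carbonyl carbon. Among the compounds with values here, no measured pair isolates this change, so the expectation rests on one indirect comparison, compound 3 at 80 nM against compound 1 at 2460 nM. Since the core of compound 3 differs, part of that gap may not carry over.

A large step toward stronger inhibition in this assay is still expected, beyond the scatter, and it is estimated as a 16-fold lower number from compound 1 to compound 4 (1.21 log units; beyond the scatter). For compound 4 the estimated value is 150 nM, with an expected range of 35 nM to 650 nM.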

Compound 4, half-maximal inhibitory concentration: 100 nM
The estimate for compound 4 lay 1.5-fold (0.18 log units) above the measured number; measured number inside the range.
By their numbers in this assay, from the lowest: compounds 3 and 4 (each within the scatter of the next); then compounds 2 and 1 (each within the scatter of the next).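

On the core of compound 1, the change of bromo to hydroxy on a saturated chain carbon bound to a carbonyl carbon can now be read as a single change in this assay, and it gives a 25-fold lower number from compound 1 to compound 4 (1.39 log units; beyond the scatter). The effect of this swap therefore no longer rests on a comparison across different cores, and the large step belongs to this one position on this core. As counted, the exchange is small, one heavy atom for one heavy atom, with hydroxy bringing a hydrogen-bond donor and a hydrogen-bond acceptor where bromo has neither, so a change of this size at this place is enough to move the number well beyond the scatter. No evidence is available on why the step is this large.

On these data alone, a single pair cannot show whether hydroxy is specifically required, so it remains open how an amine, a fluoro group, a carboxylic acid or a longer chain such as 2-hydroxyethyl would read in the same place. As far as these compounds go, it also remains open whether the same swap gives a step of similar size on the core of compound 2.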